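This account rests on a few compounds, and the source may have more. Where it says the series, first, only, none or still open, it means among the compounds named here.

In a functional assay on PC-3 cells (Homo sapiens) for inhibition, with a stated time of 48 h, tested at 50 uM (on this read-out lower numbers stand for less inhibition of growth and higher numbers for more inhibition of growth at the one concentration tested), compound 1 `C=C[C@@](C)(/C=C/c1ccc(OC(=O)CC)cc1)CCC=C(C)C` gives 54% and compound 2 `C=C[C@@](C)(/C=C/c1ccc(OC(=O)CCCC)cc1)CCC=C(C)C` gives 42%, while compound 3 `C=C[C@@](C)(/C=C/c1ccc(OC(=O)CCCCCCC)cc1)CCC=C(C)C` is lowest of the three at 22% (the nearest neighbour is compound 2). The next structure, compound 4 `C=C[C@@](C)(/C=C/c1ccc(OC)cc1)CCC=C(C)C`, has methyl in place of heptylcarbonyl on an oxygen on an aromatic ring and so loses the carbonyl as well as the chain. All three measured steps lengthen the chain and all go down: a number 12 percentage points lower from compound 1 to compound 2 (beyond the scatter) and a number 20 percentage points lower from compound 2 to compound 3 (beyond the scatter) are modest, and a number 32 percentage points lower from compound 1 to compound 3 (beyond the scatter) is large. None of them removes the carbonyl, so the reading across is loose. A large upward move is expected a number 26 percentage points higher from compound 3 to compound 4 (beyond the scatter) in this assay on this basis. The estimated value for compound 4 is 48% (range 30% to 66%).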

Compound 4, percent growth inhibition at one concentration: 44%
Estimate against measurement, compound 4: 4 percentage points above, within the range that was stated.
By their numbers in this assay, from the lowest: compound 3; then compounds 2, 4 and 1 (each within the scatter of the next, the first and the last beyond it).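

On the oxygen on an aromatic ring, methyl in place of heptylcarbonyl in this assay gives a number 22 percentage points higher from compound 3 to compound 4 (beyond the scatter), so the long acyl chain, not the mere absence of a carbonyl, separates compound 3 from compound 4. Against the shorter acyl groups, a number 2 percentage points higher from compound 2 to compound 4 (within the scatter) and a number 10 percentage points lower from compound 1 to compound 4 (within the scatter) both stay within the scatter, so methyl cannot be told apart from butylcarbonyl or propanoyl here. Nothing available explains these results.

Still open, from the compounds shown here alone, is how a free hydroxyl, an acetyl group or a chain longer than heptylcarbonyl would read on this oxygen.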